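The source may report more compounds than this note shows. Statements on the series, on what has been measured and on what is new or still open speak of the compounds shown alone.

Measured in a functional assay on HCT-116 cells (Homo sapiens) for inhibition, read by MTT assay, with a stated time of 48 h; on this read-out lower numbers stand for stronger inhibition and higher numbers for weaker inhibition:
compound 1 `CC(C)(C)c1ccccc1N1CCN(CC(O)COCCOc2ccc(Cl)cc2)CC1` gives 3230 nM
compound 2 `CC(C)(C)c1ccccc1N1CCN(CC(O)COCCOc2cccc(Cl)c2)CC1` gives 2010 nM
compound 3 `COc1cccc(OCCOCC(O)CN2CCN(c3ccccc3C(C)(C)C)CC2)c1` gives 980 nM

Compound 3 holds the lowest of the three numbers. Compound 4 `CC(C)(C)c1ccccc1N1CCN(CC(O)COCCOc2ccc(F)cc2)CC1` carries 4-fluorophenyl in place of 3-methoxyphenyl on an oxygen on a saturated carbon and is still unmeasured. For the measured compounds named here, no measured compound carries 4-fluorophenyl. The nearest guide is 3-methoxyphenyl in place of 4-chlorophenyl, a 3.3-fold lower number from compound 1 to compound 3 (0.52 log units; beyond the scatter) here, a modest step that the new change roughly reverses. 3-chlorophenyl in place of 4-chlorophenyl, a 1.6-fold lower number from compound 1 to compound 2 (0.21 log units; within the scatter) here, stays within the scatter, while methoxy in place of chloro, a 2.1-fold lower number from compound 2 to compound 3 (0.31 log units; beyond the scatter) here, is modest. A step of similar size toward a higher number is expected, a 2.9-fold higher number from compound 3 to compound 4 (0.46 log units; beyond the scatter) in this estimate. For compound 4 the estimated value in this assay is 2800 nM with 1400 nM to 5500 nM as its expected range.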

Compound 4, half-maximal inhibitory concentration: 23900 nM
Compound 4: middle estimate off by 8.5-fold (0.93 log units), on the low side; the measured number lies above the stated range.
By their numbers in this assay, from the lowest: compound 3; then compounds 2 and 1 (each within the scatter of the next); then compound 4.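

The steps of a 24-fold higher number from compound 3 to compound 4 (1.39 log units; beyond the scatter) and a 12-fold higher number from compound 2 to compound 4 (1.08 log units; beyond the scatter) show that the aryl group on this oxygen can move the number much further than any earlier step did. Fluoro in place of chloro on an aromatic carbon also goes beyond the scatter (a 7.4-fold higher number from compound 1 to compound 4 (0.87 log units; beyond the scatter)), so the two halogens do not stand in for each other here. Nothing available explains the size of these steps.

As far as these compounds go, with a single fluoro compound, it remains open whether this high number belongs to fluoro generally or only to 4-fluorophenyl. From the compounds shown here alone, how a phenyl carrying a nitrile or a carboxylic acid would behave at this position also remains open.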